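The compounds below may be only part of what the source reports. "The series", "measured", "known", "first", "only" and "open" are said of these compounds alone.

Of the compounds shown here, three with a shared core have numbers so far in an ADME assay on J774 cells (Mus musculus) for cytotoxicity, read by MTT assay, with a stated time of 48 h (a lower number here means a stronger inhibitor, a higher number a weaker inhibitor), for now. Compound 1 (`O=C(/C=C/c1ccc2no[n+]([O-])c2c1)c1ccccc1`) gives 47000 nM and compound 2 (`O=C(/C=C/c1ccc2no[n+]([O-])c2c1)c1ccc(Cl)cc1`) gives 28000 nM on the same scale. Compound 3 (`COc1ccc(C(=O)/C=C/c2ccc3no[n+]([O-])c3c2)cc1`) gives 31000 nM; 111000 nM (2 entries) as separate entries, and the several entries of compound 3 in this assay, 31000 nM; 111000 nM (2 entries) leave it without a single number to set beside compound 2. Compound 2 therefore has only compound 1 as a direct neighbour, and the two stand level: chloro in place of hydrogen on an aromatic carbon gives a 1.7-fold lower number from compound 1 to compound 2 (0.22 log units; within the scatter) and nothing more.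

Compound 4 (`O=C(/C=C/c1ccc2no[n+]([O-])c2c1)c1ccc([N+](=O)[O-])cc1`) has not yet been measured. Set against compound 2, it carries nitro in place of chloro on an aromatic carbon, para to a large group (nitro in place of chloro on an aromatic carbon). Among the measured compounds shown here, the one measured step that bears on this swap is a 1.7-fold lower number from compound 1 to compound 2 (0.22 log units; within the scatter) which also exchanges a group on an aromatic carbon. That step stays inside the scatter, but it involves a different pair of groups, so it is only a loose guide. On this evidence, no step beyond the scatter is expected in this assay and no direction can be called. That amounts to an expected 1.1-fold higher number from compound 2 to compound 4 (0.03 log units; within the scatter) and no more. The value estimated for compound 4 is 30000 nM with an expected range from 12000 nM to 75000 nM as its span.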

Compound 4, half-maximal inhibitory concentration: 32000 nM
Estimate against measurement, compound 4: 1.1-fold (0.03 log units) below, and the stated range covers the measured number.
By their numbers in this assay, from the lowest: compounds 2, 4 and 1 (each within the scatter of the next).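

In this assay, the position para to a large group on the six-membered aromatic ring now holds a second replacement for hydrogen, and nitro in place of hydrogen gives a 1.5-fold lower number from compound 1 to compound 4 (0.17 log units; within the scatter). The direct exchange of chloro for nitro, which puts a group of 3 heavy atoms and 2 hydrogen-bond acceptors where a single chlorine stood, gives a 1.1-fold higher number from compound 2 to compound 4 (0.06 log units; within the scatter). Hydrogen, chloro and nitro at this position therefore stand level across compound 1, compound 2 and compound 4, a finding that earlier rested on the chloro step alone and now holds for two different groups and for a direct swap between them.

The steps to compound 3 cannot be read, as no single number stands for it: the several entries of compound 3 in this assay, 31000 nM; 111000 nM (2 entries)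

What the compounds shown leave open is whether any group at this position can move the number beyond the scatter, for instance an amine, a carboxylic acid or a longer chain.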